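A few compounds are considered here, and "the series" means these few. Any claim that something is new, unique, unknown or untested is made for them only; others in the source may bear on it.

Compound 1 `C/N=C(/NC#N)NCCCn1nc(-c2ccccc2)ccc1=O` is the reference for this step. In a functional assay on the whole organism (stomach) with Rattus norvegicus as the target (on this read-out lower numbers stand for an effect already at smaller amounts and higher numbers for an effect only at larger amounts of compound), compound 1 gives > 100 mg/kg, which is a limit of the assay and not a number, so compound 1 stands at the edge of what the measurement can show. Two further compounds carry a related chain on the same core: compound 2 `C/N=C(/NC#N)NCCCCCn1nc(-c2ccccc2)c(C)cc1=O` and compound 3 `CC/N=C(/NC#N)NCCCCn1nc(-c2ccccc2)c(C)cc1=O`. In this assay compound 2 gives > 100 mg/kg, a limit. In this assay compound 3 gives > 100 mg/kg, again a limit. Among the measured compounds shown here, the one step that can be formed among them, a step that the two limits leave unreadable from compound 2 to compound 3, stays unreadable because the limit of > 100 mg/kg in this assay, at which 3 of the 3 values shown sit, shows every value sitting at the same limit.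

Compound 4 `N/C(S)=N/CCCCn1nc(-c2ccccc2)ccc1=O` differs from compound 1 by a group of 5 heavy atoms (2 carbon, 2 nitrogen, 1 sulfur; no ring) in place of a group of 7 heavy atoms (3 carbon, 4 nitrogen; no ring), on a saturated chain carbon, three bonds along the chain from an aromatic nitrogen. For the measured compounds named here, no measured step bears on this change; the only step available was unreadable, so no direction and no size can be drawn from the series. The estimate for compound 4 therefore rests on compound 1 alone: compound 4 is expected near 100 mg/kg, within 30 mg/kg to 300 mg/kg, which is a step of a number no higher from compound 1 to compound 4 (the limit leaves the size open) that is expected to be no more than the scatter.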

Compound 4, dose for half-maximal effect: 36.3 mg/kg
The estimate for compound 4 lay 2.8-fold (0.44 log units) above the measured number; the measured number falls inside the stated range.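

In this assay, putting the group of 5 heavy atoms (2 carbon, 2 nitrogen, 1 sulfur) in place of the group of 7 heavy atoms (3 carbon, 4 nitrogen), on a saturated chain carbon, three bonds along the chain from an aromatic nitrogen, gives an at least 2.7-fold lower number from compound 1 to compound 4 (0.44 log units; beyond the scatter). From the compounds shown here alone, compound 1 gives > 100 mg/kg, which is a limit, so the true size of this step stays open. This is the first readable step in the series, and the earlier steps cannot be read: the limit of > 100 mg/kg in this assay, at which 3 of the 4 values shown sit.

Going by these compounds, it remains open whether an amine or a carboxylic acid in the same place would also give a lower number than compound 1. Also open, on these data alone, is whether the group of compound 4 gives a similar value on the core of compound 2.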